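The compounds below may be only part of what the source reports. "The series", "measured", "known", "first", "only" and "open" are said of these compounds alone.

Compound 1 `Clc1ccc(C(c2ccccc2)(c2ccc(CN3CCCC3)cc2)n2ccnc2)cc1` — in an ADME assay on KB cells (Homo sapiens) for cytotoxicity, read by MTT assay (on this read-out lower numbers stand for higher toxicity in this test and higher numbers for lower toxicity in this test), compound 1 gives 88.1 uM.
Compound 2 `Clc1ccc(C(Nc2ccnc3cc(Cl)ccc23)c2ccc(CN3CCCC3)cc2)cc1` — in this assay compound 2 gives 19.6 uM.
Compound 3 `Clc1cccc(C(Nc2ccnc3cc(Cl)ccc23)c2ccc(CN3CCCC3)cc2)c1` — in this assay compound 3 is recorded as "not determined" (no result reported), so no result is reported for it.

Compound 2 stands at the lowest of the two numbers in this assay; compound 1 gives the higher number, and that gap lies beyond the scatter. Compound 4 `Clc1ccc(C(Nc2ccnc3cc(Cl)ccc23)(c2ccccc2)c2ccc(CN3CCCC3)cc2)cc1` differs from compound 2 by phenyl in place of hydrogen on a saturated chain carbon bound to two aromatic carbons and a nitrogen on an aromatic ring. For the measured compounds named here, no measured pair shows this change on its own, so the size of the step in this assay is uncertain; a modest shift, if any, is expected, with a lower number somewhat more likely than a higher one. Compound 4 is therefore estimated at 15 uM (range 6 uM to 45 uM). The expected step from compound 2 to compound 4 is a 1.3-fold lower number from compound 2 to compound 4 (0.12 log units; within the scatter).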

Compound 4, half-maximal toxic concentration: 207 uM
Estimate against measurement, compound 4: 14-fold (1.14 log units) below, outside the stated range (above it).
By their numbers in this assay, from the lowest: compound 2; then compound 1; then compound 4.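

Phenyl in place of hydrogen on a saturated chain carbon bound to two aromatic carbons and a nitrogen on an aromatic ring brings an 11-fold higher number from compound 2 to compound 4 (1.02 log units; beyond the scatter) in this assay and so shows that this position responds strongly to this change. (7-chloroquinolin-4-yl)amino in place of 1H-imidazol-1-yl on a saturated chain carbon bound to three aromatic carbons brings a 2.3-fold higher number from compound 1 to compound 4 (0.37 log units; beyond the scatter) which is a modest step by comparison. Nothing measured here gives a cause for either step.

Going by these compounds, whether methyl or a hydroxyl group on this carbon would bring a step of similar size stays open, as does whether phenyl would have the same effect on compound 3.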